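The compounds below may be only part of what the source reports. "The series", "measured", "known", "first", "only" and "open" are said of these compounds alone.

Compound 1 `CC(C#CCn1ccnc1)N1CCCC1=O` gives 3.7 mg/kg in a functional assay on the whole organism for antagonist activity, with Mus musculus as the target; a higher number here means that more compound is needed for the effect, a lower number that less compound is needed. Compound 2 `CC(C#CCN(C)C)N1CCCC1=O` is its analogue with dimethylamino in place of 1H-imidazol-1-yl on a saturated chain carbon bound to a triple-bonded carbon. In this assay compound 2 reaches only the limit of > 100 mg/kg. That change made an at least 27-fold higher number from compound 1 to compound 2 (1.43 log units; beyond the scatter), and the limit of > 100 mg/kg in this assay, at which 2 of the 3 values shown sit, is where compound 2 sits. Compound 3 `COC(=O)N(C)CC#CCn1ccnc1` has a different core; how it differs from compound 1 is not broken down here. In this assay compound 3 gives only the limit of > 100 mg/kg. Compound 4 `COC(=O)N(C)CC#CCN(C)C` is related to compound 3 by the same change, (dimethylamino in place of 1H-imidazol-1-yl on a saturated chain carbon bound to a triple-bonded carbon), at the same place. Compound 4 is therefore expected to sit at that limit as well, estimated at 300 mg/kg. This expectation rests on an at least 27-fold higher number from compound 1 to compound 2 (1.43 log units; beyond the scatter) and means an expected step that the limit leaves unreadable from compound 3 to compound 4.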

Compound 4, dose for half-maximal effect: > 30 mg/kg
Compound 4: a limit, no number; the forecaster's own chance of this, stated with the estimate: 90%; the middle value is on the limit's open side.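

In this assay, compound 3 and compound 4 both give only limits, not numbers, so no step can be read between them. As far as these compounds go, whether dimethylamino in place of 1H-imidazol-1-yl changes the dose on the core of compound 3 stays open.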